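A few compounds are considered here, and "the series" means these few. Any claim that something is new, unique, unknown or untested is made for them only; others in the source may bear on it.

In a functional assay on PC-3 cells (Homo sapiens) for cytotoxicity, read by sulforhodamine B assay, with a stated time of 48 h (on this read-out higher numbers stand for weaker inhibition and lower numbers for stronger inhibition), compound 1 `COc1cc(NC(=O)[C@H]2CSC(c3ccccc3)=N2)cc(OC)c1OC` gives 13200 nM, the higher of the two actual numbers available. Compound 3 `CCc1ccc(-c2nc(C(=O)c3cc(OC)c(OC)c(OC)c3)cs2)cc1` gives 27 nM, a far lower number and a gap well beyond the scatter. Compound 2 `COc1cc(NC(=O)[C@@H]2CSC(c3ccccc3)N2)cc(OC)c1OC` yields only a limit, > 20000 nM, rather than a number.

The next compound to be tested is compound 4 `COc1cc(NC(=O)[C@@H]2CSC(c3ccccc3)=N2)cc(OC)c1OC`, the stereochemical counterpart of compound 1. The comparison is the two compounds have the same atoms and bonds and differ only in configuration as drawn: 1 of 1 stereo elements differ; a stereocentre at a saturated ring carbon is drawn S in compound 1 and R in compound 4: the two compounds have the same atoms and bonds, and a stereocentre at a saturated ring carbon is drawn S in compound 1 and R in compound 4.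

For the measured compounds named here, none of the compounds measured so far forms a pair differing only in configuration, so this assay offers no direct guide to the size of this change. The expectation therefore starts from compound 1 at 13200 nM, with compound 4 assumed to remain in the same weak range. The expected step, a 1.2-fold lower number from compound 1 to compound 4 (0.08 log units; within the scatter), is estimated to lie within the scatter, with no direction favoured. A result reported only as a limit would also be plausible. For compound 4, the expected value is 11000 nM, with an estimated range of 4000 nM to 20000 nM.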

Compound 4, half-maximal inhibitory concentration: > 20000 nM
Compound 4 was reported as a limit (the forecaster's own chance of this, stated with the estimate: 25%); middle value at least 1.8-fold (0.25 log units) away from the limit.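

In this assay compound 4 stands at > 20000 nM, which is a limit of the assay and not a number, so the change at this stereocentre from S to R can be read only as a floor: the limit of > 20000 nM in this assay, at which 2 of the 4 values shown sit. That floor is an at least 1.5-fold higher number from compound 1 to compound 4 (0.18 log units; that floor lies within the scatter), so the data show no change beyond the scatter, but they do show that drawing this saturated ring carbon as R brings no move towards stronger inhibition. The earlier compounds shown here offered no direct reading of configuration at this position, and here nothing else varies: the fact that compounds 1 and 4 differ only in the configuration as drawn.

On these data alone, how far compound 4 actually lies past its limit remains open, and with it the true size of the step and whether the configuration at this carbon matters at all in this assay. Also open, as far as these compounds go, is whether the two configurations would separate more clearly in a series with stronger inhibition, for example with an amine or a carboxylic acid carried on the core of compound 1.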